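The source may hold more compounds than are shown below. What is called first, only, known or untested is meant among the compounds shown, and "the series" means these compounds.

Of the compounds shown here, two have so far been tested in a functional assay on HOS-TE85 cells (Homo sapiens) for inhibition, read by CCK-8 assay, with a stated time of 72 h (on this read-out lower numbers stand for stronger inhibition and higher numbers for weaker inhibition), and both came back at the edge of what the test can report. Compound 1 `COc1ccccc1N1C(=O)CSC1c1cc(F)cc(C(=O)O)c1` gives > 1000 nM, which is a limit of the test rather than a measured number. Compound 2 `COc1cccc(OC)c1N1C(=O)CSC1c1cccc(C(=O)NCCCCc2ccccc2)c1` likewise gives > 1000 nM, again a limit and not a number. Compound 2 therefore stands at the weak end of what can be seen here, and the same holds for compound 1: the limit of > 1000 nM in this assay, at which 2 of the 2 values shown sit, so no numbered value exists yet to compare against.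

Compound 3 `COc1c(F)cccc1N1C(=O)CSC1c1cccc(C(=O)NCCCCc2ccccc2)c1` is reached from compound 2 by one change: 3-fluoro-2-methoxyphenyl in place of 2,6-dimethoxyphenyl on an amide-type nitrogen in a ring. The rest of the structure is kept unchanged. For the measured compounds named here, with no measured step between two numbered compounds to lean on, the expectation in this assay is for no change beyond the scatter, and a step that the limit leaves unreadable from compound 2 to compound 3 is expected to be small. Compound 3 is accordingly estimated at 3000 nM, with a range from 1000 nM to 10000 nM, and most likely it too will be reported only as a limit.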

Compound 3, half-maximal inhibitory concentration: 26.2 nM
Estimate against measurement, compound 3: 110-fold (2.06 log units) above; measured number outside the range, below it.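

The group on the amide-type nitrogen of the five-membered ring is clearly a place where this assay responds strongly: putting 3-fluoro-2-methoxyphenyl in place of 2,6-dimethoxyphenyl, with the rest of the structure unchanged, gives an at least 38-fold lower number from compound 2 to compound 3 (1.58 log units; beyond the scatter). For the compounds shown here, with this change, compound 3 provides the first numbered value of the series at 26.2 nM, showing that strong inhibition in these cells is possible with this shared core. The step can only be read as a minimum, because compound 2 is reported as a limit and not as a number: the limit of > 1000 nM in this assay, at which 2 of the 3 values shown sit.

The change removes one methoxy group and brings in a fluorine, so the compounds shown cannot say whether the loss, the gain or the two together account for the step; a plain 2-methoxyphenyl or a 3-chloro-2-methoxyphenyl group at this place would help to separate them. As far as these compounds go, it also remains open how much the long phenyl-bearing amide chain contributes, and whether a shorter chain or an amine at its end would keep the value of compound 3.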